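The compounds below may be only part of what the source reports. "The series", "measured", "known", "first", "only" and "open" are said of these compounds alone.

Among the three compounds measured so far in a functional assay on U-373MG ATCC cells for inhibition, with U373 MG (Homo sapiens) as the target, read by MTT assay, with a stated time of 72 h (on this read-out higher numbers stand for weaker inhibition of growth and lower numbers for stronger inhibition of growth), compound 3 `CC(C)=CCC/C(C)=C/C(=O)NC(=N)NC(=O)/C=C(\C)CCC=C(C)C` carries the largest of the three numbers: compound 3 gives 38900 nM, compound 2 `CC(C)=CCC/C(C)=C/C(=O)NC(=N)NC(=O)C=C(C)C` gives 36200 nM, and compound 1 `CC(C)=CCC/C(C)=C/CC/C(C)=C/C(=O)NC(=N)NC(=O)C=C(C)C` gives 15700 nM. The gap from compound 3 to compound 2 lies within the scatter, the gap to compound 1 beyond it. Compound 4 `CC(C)=CCC/C(C)=C/CC/C(C)=C/C(=O)NC(=N)NC(=O)/C=C(\C)CCC=C(C)C` differs from compound 3 by 3-methylbut-2-en-1-yl in place of hydrogen on a saturated chain carbon bound to a double-bonded chain carbon. Within the data shown here, two measured steps bear on this. Going the opposite way, a 2.3-fold higher number from compound 1 to compound 2 (0.36 log units; beyond the scatter), a modest step beyond the scatter, whereas the same addition gave a 1.1-fold higher number from compound 2 to compound 3 (0.03 log units; within the scatter), within the scatter. Because a 2.3-fold higher number from compound 1 to compound 2 (0.36 log units; beyond the scatter) is the closer precedent, a modest move toward stronger inhibition of growth is expected, roughly a 2.2-fold lower number from compound 3 to compound 4 (0.33 log units; beyond the scatter). Compound 4 is therefore estimated at about 18000 nM, with a likely range from 8000 nM to 40000 nM.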

Compound 4, concentration for 50% growth inhibition: 35000 nM
Beside the measured number, compound 4's estimate is 1.9-fold (0.29 log units) below it, and the stated range covers the measured number.
By their numbers in this assay, from the lowest: compound 1; then compounds 4, 2 and 3 (each within the scatter of the next).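

On the core of compound 3, 3-methylbut-2-en-1-yl gives a 1.1-fold lower number from compound 3 to compound 4 (0.05 log units; within the scatter), so the modest gain seen between compound 2 and compound 1 does not appear here. Using 3,7-dimethylocta-2,6-dien-1-yl in place of hydrogen gives a 1.0-fold lower number from compound 2 to compound 4 (0.01 log units; within the scatter), while adding 3-methylbut-2-en-1-yl to the other chain gives a 2.2-fold higher number from compound 1 to compound 4 (0.35 log units; beyond the scatter), so only compound 1 stands apart. Even so, the effect of this change on the two cores cannot be firmly told apart: the same change on two cores in this assay, a 2.3-fold higher number (0.36 log units; beyond the scatter) from compound 1 to compound 2 and a 1.1-fold higher number (0.05 log units; within the scatter) from compound 4 to compound 3, 2.1-fold (0.32 log units) apart, within the scatter of two such steps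

Open, on these data alone, is whether a chain ending in an amine or a carboxylic acid would lower the number at this place, and whether a longer chain would.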